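Sulfonyl aryl exchange from compound 1: working notes

This account rests on a few compounds, and the source may have more. Where it says the series, first, only, none or still open, it means among the compounds named here.

Among the compounds with values here, compound 1 `CC1CCN(c2c(S(=O)(=O)c3cc(F)cc(F)c3)cnc3cc(Cl)ccc23)CC1` gives 94% in an assay on isolated protein for displacement of a labelled ligand from metabotropic glutamate receptor 5 (Homo sapiens), with a stated time of 60 min, tested at 1 uM (a higher number here means more inhibition at the concentration tested (going by the name of the read-out), a lower number less inhibition), the highest of the three numbers measured so far. Within the data shown here, compound 3 `COc1ccc2ncc(S(=O)(=O)c3ccc(Cl)cc3)c(N3CCC(C)CC3)c2c1` gives 91%, within the scatter of compound 1; compound 2 `CC1CCN(c2c(S(=O)(=O)c3cc(F)cc(F)c3)cnc3cc(F)ccc23)CC1` gives 77%, and the step of a number 17 percentage points lower from compound 1 to compound 2 (beyond the scatter) is the only single-point change measured. Compound 4 `Cc1ccc(S(=O)(=O)c2cnc3cc(Cl)ccc3c2N2CCC(C)CC2)cc1C` differs from compound 1 by 3,4-dimethylphenyl in place of 3,5-difluorophenyl on a sulfonyl sulfur. No measured step touches the group on the sulfonyl sulfur, so nothing shown bears directly on this change; compound 3 only indicates that a different aryl group on the sulfonyl sulfur can keep the read-out high. The expected step of a number 9 percentage points lower from compound 1 to compound 4 (within the scatter) is therefore small, with a slight downward lean. Compound 4 is estimated at 85%, range 65% to 97%.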

Compound 4, a percentage reported as inhibition, at one concentration (the size of the read-out at that concentration, not a potency): 86%
The estimate for compound 4 lay 1 percentage points below the measured number; the range from low to high includes it.
By their numbers in this assay, from the lowest: compounds 2, 4, 3 and 1 (each within the scatter of the next, the first and the last beyond it).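

In this assay, within the data shown here, 3,4-dimethylphenyl in place of 3,5-difluorophenyl on a sulfonyl sulfur gives a number 8 percentage points lower from compound 1 to compound 4 (within the scatter) as the first direct reading at this position. On the core of compound 1, an aryl group without fluorine therefore holds the read-out within the scatter of the difluorophenyl group. No available evidence accounts for this result.

On these data alone, whether a saturated group such as cyclohexyl, or an aryl group carrying an amine or a carboxylic acid, keeps the read-out high remains open. Also open, as far as these compounds go, is whether the exchange holds with fluoro in place of chloro on the core.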